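Swapping a Benzyl Arm for a Phenoxy Arm

The compounds below may be only part of what the source reports. "The series", "measured", "known", "first", "only" and "open" are said of these compounds alone.

Measured compounds in an ADME assay on HepG2 cells (Homo sapiens) for cytotoxicity, read by luminescence, CellTiter-Glo and ATP content, with a stated time of 72 h; a lower number here means that less compound is needed, a higher number that more compound is needed for the effect:
Compound 1 `COc1cccc(Oc2ccc3c(NCCCNCc4cccc(OC)c4O)ccnc3c2)c1` gives 5300 nM.
Compound 2 `COc1cccc(CNCCCNc2ccnc3cc(Cc4ccc(C#N)cc4)ccc23)c1O` gives 7150 nM.

Among the compounds with values here, the only measured step is a 1.3-fold higher number from compound 1 to compound 2 (0.13 log units; within the scatter), so the two numbers stand level. Compound 3 `COc1cccc(CNCCCNc2ccnc3cc(Oc4ccc(Cl)cc4)ccc23)c1O` differs from compound 2 by 4-chlorophenoxy in place of 4-cyanobenzyl on an aromatic carbon. That one measured step, which swapped a group at the same aromatic carbon, stayed within the scatter, and compound 1 already carries a 3-methoxyphenoxy group there at a similar number. No step beyond the scatter is therefore expected in this assay. Compound 3 is estimated at 6000 nM, within 3000 nM to 12000 nM, which means an expected step of a 1.2-fold lower number from compound 2 to compound 3 (0.08 log units; within the scatter).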

Compound 3, half-maximal effective concentration: 5700 nM
Estimate against measurement, compound 3: 1.1-fold (0.02 log units) above; low and high end bracket the measured number.
By their numbers in this assay, from the lowest: compounds 1, 3 and 2 (each within the scatter of the next).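

In this assay the arm on this aromatic carbon can change from 4-cyanobenzyl to 4-chlorophenoxy with the numbers staying level (a 1.3-fold lower number from compound 2 to compound 3 (0.10 log units; within the scatter)). A change within the phenoxy arm, 4-chlorophenyl in place of 3-methoxyphenyl on the oxygen, also stays within the scatter (a 1.1-fold higher number from compound 1 to compound 3 (0.03 log units; within the scatter)), so all three arms read alike here. No measurement shown here explains why these numbers stand level.

As far as these compounds go, it remains open whether this holds for an arm of a different kind at this carbon, such as an amine or a carboxylic acid.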